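Moving the methoxy group within a sulfonamide series

This account rests on a few compounds, and the source may have more. Where it says the series, first, only, none or still open, it means among the compounds named here.

Among the measured compounds shown here, compound 2 `COc1cccc(CNCCCNS(=O)(=O)c2cc(C(F)(F)F)cc(C(F)(F)F)c2)c1` gives 6400 nM in a functional assay on Capan-2 cells (Homo sapiens) for inhibition, read by MTT assay, with a stated time of 72 h (a higher number here means a weaker inhibitor of growth, a lower number a stronger inhibitor of growth), the higher of the two numbers known, above compound 1 `O=S(=O)(NCCCNCc1ccc(Br)cc1)c1cc(C(F)(F)F)cc(C(F)(F)F)c1` at 2000 nM. Compound 3 `COc1ccccc1CNCCCNS(=O)(=O)c1cc(C(F)(F)F)cc(C(F)(F)F)c1` carries 2-methoxyphenyl in place of 3-methoxyphenyl on a saturated chain carbon bound to an amine nitrogen. For the measured compounds named here, only one measured step bears on this region: a 3.2-fold higher number from compound 1 to compound 2 (0.51 log units; beyond the scatter), showing that swapping the aryl group here shifts the read-out modestly. Going by the values given here, no measured step exchanges one methoxyphenyl for another. The expected step is therefore a 1.3-fold lower number from compound 2 to compound 3 (0.11 log units; within the scatter), small and within or near the scatter. The estimate for compound 3 in this assay is 5000 nM, ranging from 1800 nM to 14000 nM.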

Compound 3, concentration for 50% growth inhibition: 6000 nM
Estimate against measurement, compound 3: 1.2-fold (0.08 log units) below, within the range that was stated.
By their numbers in this assay, from the lowest: compound 1; then compounds 3 and 2 (each within the scatter of the next).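

In this assay, the position on a saturated chain carbon bound to an amine nitrogen tolerates the exchange of 3-methoxyphenyl for 2-methoxyphenyl with no change beyond the scatter (a 1.1-fold lower number from compound 2 to compound 3 (0.03 log units; within the scatter)). The gap from the 4-bromophenyl compound is also not particular to 3-methoxyphenyl, since it appears with 2-methoxyphenyl as well (a 3.0-fold higher number from compound 1 to compound 3 (0.48 log units; beyond the scatter)). Nothing given here explains these numbers. Going by these compounds, whether 4-methoxyphenyl would read with the other two methoxyphenyl compounds or with compound 1 remains open, as does the outcome of a longer chain.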